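Swapping a halogen on an arylidene diketopiperazine

The source may report more compounds than this note shows. Statements on the series, on what has been measured and on what is new or still open speak of the compounds shown alone.

Measured compounds:
- compound 1, `COc1ccccc1/C=c1/[nH]c(=O)/c(=C\c2ccccc2OC)n(C)c1=O`: "not determined" (no result reported) in a functional assay on MOLT-4 cells (Homo sapiens) for cytotoxicity, read by CCK-8 assay, with a stated time of 72 h; on this read-out higher numbers stand for weaker inhibition and lower numbers for stronger inhibition
- compound 2, `C=CCn1c(=O)/c(=C\c2ccccc2Cl)[nH]c(=O)/c1=C\c1ccccc1OC`: 4400 nM

Compound 1 carries two methoxyphenyl arms on the shared core, yet for it this assay gives "not determined" (no result reported) and no number at all. For the measured compounds named here, compound 2 is therefore the only compound with a measured value here. In this assay, going by the values given here, compound 2 gives 4400 nM, and with nothing else to set beside it, no ranking among the compounds can be drawn.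

Compound 3, `C=CCn1c(=O)/c(=C\c2ccccc2F)[nH]c(=O)/c1=C\c1ccccc1OC`, is a close relative of compound 2. The single difference between them is:

fluoro in place of chloro on an aromatic carbon

In other words the 2-chlorophenyl of compound 2 becomes a 2-fluorophenyl in compound 3, one halogen for another at the same aromatic carbon. Among the compounds with values here, no measured pair in this set shows what such a swap does to the read-out, so the direction of the step cannot be taken from the data. A change this small is expected to move the number little, if at all, so the estimated step from compound 2 to compound 3 is a 1.4-fold higher number from compound 2 to compound 3 (0.13 log units; within the scatter), a shift that may sit within the usual scatter. On that basis compound 3 is expected to show about 6000 nM, with a likely range from 2000 nM to 18000 nM.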

Compound 3, half-maximal inhibitory concentration: 20000 nM
The estimate for compound 3 lay 3.3-fold (0.52 log units) below the measured number; measured number outside the range, above it.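

In this assay, the halogen on this aromatic carbon, ortho to a large group, proves to matter: putting fluoro in place of chloro gives a 4.5-fold higher number from compound 2 to compound 3 (0.66 log units; beyond the scatter), so the 2-chlorophenyl compound holds the lower number, which here stands for stronger inhibition. For the compounds shown here, the exchange is very small, one heavy atom for one heavy atom, with no ring, hydrogen-bond donor, hydrogen-bond acceptor or net charge entering or leaving, yet the step lies beyond the usual scatter, something the earlier compounds, with only one number between them, could not show. No measurement at hand accounts for the step.

As far as these compounds go, with only chloro and fluoro compared at this position, it remains open whether bromo would continue the same order, or how a group other than a halogen, such as methyl or an amine, would read out. From the compounds shown here alone, compound 1 has no number in this assay, so the effect of a 2-methoxyphenyl in this place also stays unknown, as does whether the same halogen swap would give a similar step on a different arm of the shared core.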